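The compounds below may be only part of what the source reports. "The series", "measured", "known", "first", "only" and "open" are said of these compounds alone.

Within the data shown here, compound 1 `Cc1noc(NS(=O)(=O)c2ccc(NCc3ccccc3)cc2)c1C` sits at the weak end of the three numbers so far: in an assay on VSM-A10 cells for antagonist activity at Endothelin-1 receptor (Rattus norvegicus) (on this read-out higher numbers stand for weaker inhibition and lower numbers for stronger inhibition), compound 1 gives 9800 nM. Compound 3 `Cc1noc(NS(=O)(=O)c2cccc([N+](=O)[O-])c2)c1C` lies within the scatter of it, since in this assay compound 3 gives 7800 nM, so no order can be read between these two. Compound 2 `CCCCCNc1cccc2c(S(=O)(=O)Nc3onc(C)c3C)cccc12` stands far apart, because in this assay compound 2 gives 80 nM; it differs from compound 1 in more than one place, so its gap cannot be assigned to a single change.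

Compound 4 `CCCNc1ccc(S(=O)(=O)Nc2onc(C)c2C)cc1` is the one left to measure. It differs from compound 1 as follows: ethyl in place of phenyl on a saturated chain carbon bound to a nitrogen on an aromatic ring. Among the measured compounds shown here, no pair of measured compounds shows this exact change, so there is nothing to lean on for its size. The account expects the step from compound 1 to compound 4 to be a 1.6-fold lower number from compound 1 to compound 4 (0.21 log units; within the scatter), a movement that is not clearly beyond the scatter in either direction. Compound 4 is therefore estimated at 6000 nM in this assay, with a range from 1500 nM to 20000 nM.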

Compound 4, half-maximal inhibitory concentration: 27000 nM
Beside the measured number, compound 4's estimate is 4.5-fold (0.65 log units) below it, and the stated range ends below it.
By their numbers in this assay, from the lowest: compound 2; then compounds 3 and 1 (each within the scatter of the next); then compound 4.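

In this assay, replacing phenyl with ethyl on a saturated chain carbon bound to a nitrogen on an aromatic ring gives a 2.8-fold higher number from compound 1 to compound 4 (0.44 log units; beyond the scatter) and so moves the number beyond the scatter, though only modestly. Among these compounds, this is the first sign that the group at this position matters, with the phenyl of compound 1 giving stronger inhibition than the ethyl of compound 4, even though compound 1 already sits at the weak end of the series. Nothing available explains why this change moves the number.

Only phenyl and ethyl are shown at this place, so a longer chain, a cyclohexyl group or a phenyl carrying a carboxylic acid might each read differently. As far as these compounds go, whether the same change would have a similar effect on the core of compound 2 also remains open.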